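Furan-3-yl for 3-chlorophenyl on the shared core

The source may hold more compounds than are shown below. What is called first, only, known or untested is meant among the compounds shown, and "the series" means these compounds.

Measured so far:
compound 1 `COc1cc(CC(O)c2ccc(-c3cccc(Cl)c3)cc2)c([N+](=O)[O-])cc1OC`, 5900 nM
compound 2 `COc1cc(CC(O)c2cccc(-c3ccc(C#N)cc3)c2)c([N+](=O)[O-])cc1OC`, 9300 nM

In an ADME assay on HeLa Rh cells (Homo sapiens) for cytotoxicity, read by microscopy (a higher number here means that more compound is tolerated, a lower number that less compound is tolerated), compound 1 gives 5900 nM and compound 2 gives 9300 nM; the two numbers lie within the scatter of each other, so neither stands apart. Compound 3 `COc1cc(CC(O)c2ccc(-c3ccoc3)cc2)c([N+](=O)[O-])cc1OC` has not yet been measured. It differs from compound 1 in one place: furan-3-yl in place of 3-chlorophenyl on an aromatic carbon. Within the data shown here, no step between measured compounds covers this change, so only a modest step is expected, towards a somewhat higher number, of about a 1.4-fold higher number from compound 1 to compound 3 (0.13 log units; within the scatter) in this assay. For compound 3 the estimate is 8000 nM, in the range 3500 nM to 20000 nM.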

Compound 3, half-maximal cytotoxic concentration: 5300 nM
Compound 3: the middle estimate sits 1.5-fold (0.18 log units) above what was measured, within the range that was stated.
By their numbers in this assay, from the lowest: compounds 3, 1 and 2 (each within the scatter of the next).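

In this assay, furan-3-yl in place of 3-chlorophenyl on this aromatic carbon, para to a large group, gives a 1.1-fold lower number from compound 1 to compound 3 (0.05 log units; within the scatter). At this position, then, a five-membered aromatic ring with 1 hetero atom and a six-membered aromatic ring of carbon only are not told apart by this read-out, despite the added hydrogen-bond acceptor and the loss of chlorine. No supporting measurement accompanies this step to account for it.

Open, on these data alone, is whether a non-aromatic group at this position, such as an amine or a carboxylic acid, would give a step beyond the scatter.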